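Swapping the Indole Back to a Chlorinated Phenyl

The source may report more compounds than this note shows. Statements on the series, on what has been measured and on what is new or still open speak of the compounds shown alone.

Compound 1 `O=C(/C(=C\c1ccc(Cl)cc1)Sc1ccc(Cl)cc1)c1ccc(Cl)cc1`: 1000 nM
Compound 2 `Cc1ccc(CS/C(=C/c2ccc(Br)cc2)C(=O)c2ccc(Cl)cc2)cc1`: 10000 nM
Compound 3 `Cc1ccc(CS/C(=C/c2c[nH]c3ccc(Cl)cc23)C(=O)c2ccc(Cl)cc2)cc1`: 1000 nM

These values come from a functional assay on DU-145 cells (Homo sapiens) for inhibition, read by trypan blue exclusion, with a stated time of 96 h; on this read-out lower numbers stand for stronger inhibition of growth and higher numbers for weaker inhibition of growth. Compound 3 stands level with compound 1, and together they hold the lowest number of the three. Compound 4 `Cc1ccc(CS/C(=C/c2ccc(Cl)cc2)C(=O)c2ccc(Cl)cc2)cc1` is still unmeasured. It differs from compound 3 by one change: 4-chlorophenyl in place of 5-chloro-1H-indol-3-yl on a double-bonded chain carbon bound to a double-bonded chain carbon. In words, 4-chlorophenyl takes the place of 5-chloro-1H-indol-3-yl on a double-bonded chain carbon bound to a double-bonded chain carbon.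

The closest guide is a 10-fold lower number from compound 2 to compound 3 (1.00 log units; beyond the scatter). That step brought in the same 5-chloro-1H-indol-3-yl, replacing 4-bromophenyl. The change to compound 4 runs roughly the other way, so a step of similar size towards a higher number in this assay is expected. Compound 1 also carries 4-chlorophenyl in that place and gives 1000 nM, but it differs elsewhere, so the expected rise may be somewhat smaller. The estimated change is a 6.0-fold higher number from compound 3 to compound 4 (0.78 log units; beyond the scatter). For compound 4 the estimate is 6000 nM, with an expected range of 2000 nM to 15000 nM.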

Compound 4, concentration for 50% growth inhibition: 10000 nM
Estimate against measurement, compound 4: 1.7-fold (0.22 log units) below; the measured number falls inside the stated range.
By their numbers in this assay, from the lowest: compounds 1 and 3 (each within the scatter of the next); then compounds 2 and 4 (each within the scatter of the next).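

In this assay, a 10-fold higher number from compound 3 to compound 4 (1.00 log units; beyond the scatter) shows that, with 4-methylbenzyl on the sulfur, the lower number depends on the 5-chloro-1H-indol-3-yl group and not simply on having a chlorine-bearing ring at this double-bonded chain carbon. The halogen on the phenyl ring makes no visible difference, since chloro in place of bromo on an aromatic carbon gives no change at the digits printed from compound 2 to compound 4 (within the scatter). With 4-chlorophenyl held at this chain carbon, the group on the sulfur also counts, as 4-methylbenzyl in place of 4-chlorophenyl gives a 10-fold higher number from compound 1 to compound 4 (1.00 log units; beyond the scatter).

Nothing measured here gives a reason for these steps. Still open, from the compounds shown here alone, is whether the indole would lower the number with 4-chlorophenyl on the sulfur, and how a phenyl ring carrying an amine or a carboxylic acid would behave at this chain carbon.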